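The compounds below may be only part of what the source reports. "The series", "measured", "known", "first", "only" and "open" are said of these compounds alone.

Measured in an ADME assay on Vero cells (Chlorocebus sabaeus) for cytotoxicity, read by MTT assay; on this read-out higher numbers stand for lower toxicity in this test and lower numbers for higher toxicity in this test:
Compound 1 `Cn1nc(C(F)(F)F)cc1C(=O)Nc1ccc(S(=O)(=O)N2CCCCC2)cc1`: > 300000 nM, a limit.
Compound 2 `Cn1nc(C(F)(F)F)cc1C(=O)Nc1ccc(S(=O)(=O)NC2CCCCC2)cc1`: 15000 nM.
Compound 3 `Cn1nc(C(F)(F)F)cc1C(=O)Nc1ccc(S(=O)(=O)OC2CCCCC2)cc1`: > 300000 nM, a limit.

Compound 1 has no number, only a limit: it stands at the limit of > 300000 nM in this assay, at which 2 of the 3 values shown sit. Compound 4 `Cn1nc(C(F)(F)F)cc1C(=O)Nc1ccc(S(=O)(=O)N2CCC(NC(=O)OC(C)(C)C)CC2)cc1` carries (tert-butoxycarbonyl)amino in place of hydrogen on a saturated ring carbon. Going by the values given here, no measured step touches that carbon. The nearest evidence lies on the sulfonyl sulfur, where the steps were large: an at least 20-fold lower number from compound 1 to compound 2 (1.30 log units; beyond the scatter) and an at least 20-fold higher number from compound 2 to compound 3 (1.30 log units; beyond the scatter), while a step that the two limits leave unreadable from compound 1 to compound 3. Compound 4 keeps the attachment of compound 1 there, so only a modest fall is expected, and a second limit reading is quite possible: an at least 1.5-fold lower number from compound 1 to compound 4 (0.17 log units; that floor lies within the scatter). For compound 4 the estimated value is 200000 nM, within an expected range from 40000 nM to 500000 nM.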

Compound 4, half-maximal cytotoxic concentration: > 300000 nM
Compound 4: no number, only a limit (the forecaster's own chance of this, stated with the estimate: 55%); middle value at least 1.5-fold (0.17 log units) away from the limit.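

In this assay compound 4 gives > 300000 nM as a limit only. Compound 1 also stands at a limit, so no step from compound 1 to compound 4 can be read: the limit of > 300000 nM in this assay, at which 3 of the 4 values shown sit.

From the compounds shown here alone, whether (tert-butoxycarbonyl)amino in place of hydrogen on that saturated ring carbon changes the read-out at all stays open.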